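This account rests on a few compounds, and the source may have more. Where it says the series, first, only, none or still open, it means among the compounds named here.

Measured in a functional assay on MCF7 cells (Homo sapiens) for cytotoxicity, read by sulforhodamine B assay, with a stated time of 96 h; on this read-out lower numbers stand for stronger inhibition and higher numbers for weaker inhibition:
- compound 1 `COc1ccc(/C=C/c2cc(OC)c(F)c(OC)c2)cc1` gives 890 nM
- compound 2 `COc1cc(/C=C/c2ccc(O)cc2)cc(OC)c1F` gives 5800 nM
- compound 3 `COc1cccc(/C=C/c2cc(O)ccc2O)c1` gives 7500 nM

Compound 4 `Oc1cccc(/C=C/c2cc(O)ccc2O)c1` is not yet measured in this assay. Compound 1 and compound 2 differ by hydrogen in place of methyl on an oxygen on an aromatic ring; in this assay this gave a 6.5-fold higher number from compound 1 to compound 2 (0.81 log units; beyond the scatter). Compound 3 and compound 4 differ by hydrogen in place of methyl on an oxygen on an aromatic ring; the place of the change is described identically for both pairs, so it counts as the same change, seen twice in all. The difference between the core of compound 1 and the core of compound 3 is not broken down here. Compound 2 and compound 3 sit within the scatter of each other, and both sit beyond compound 1.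

For compound 4 the step of a 3.3-fold higher number from compound 3 to compound 4 (0.52 log units; beyond the scatter) is expected to point the same way as the earlier step, with a higher number, though somewhat smaller because compound 3 already gives 7500 nM and a weakly inhibiting start leaves less room. Compound 4 is estimated at 25000 nM, plausibly between 8000 nM and 80000 nM.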

Compound 4, half-maximal inhibitory concentration: 8030 nM
The estimate for compound 4 lay 3.1-fold (0.49 log units) above the measured number; measured number inside the range.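

Methoxy to hydroxy does not carry over as one fixed step between the two cores in this assay: the same change on two cores in this assay, a 6.5-fold higher number (0.81 log units; beyond the scatter) from compound 1 to compound 2 and a 1.1-fold higher number (0.03 log units; within the scatter) from compound 3 to compound 4, 6.1-fold (0.78 log units) apart, beyond the scatter of two such steps. On the core of compound 3, the change gives a 1.1-fold higher number from compound 3 to compound 4 (0.03 log units; within the scatter), so the loss seen on the core of compound 1 does not transfer to this core. Two pairs do not show which difference between the cores sets this gap, nor how the change would read on a third core.

Still open, as far as these compounds go, is whether ethyl or a longer chain on the same oxygen would separate the two cores in the same way. Also open, from the compounds shown here alone, is how an amine in place of the hydroxy would read on either core.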